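The compounds below may be only part of what the source reports. "The series", "measured", "known", "first", "only" and "open" are said of these compounds alone.

Compound 1, `Cc1cccc(NC(=O)CN2CCC(c3nccs3)CC2)c1`: 1 nM
Compound 2, `c1ccc(C2CCN(Cc3nc4ccccc4[nH]3)CC2)nc1`: 12 nM

Both numbers come from a functional assay on HEK293 cells for agonist activity at D(4) dopamine receptor (Homo sapiens), read by FLIPR; on this read-out higher numbers stand for an effect only at larger amounts of compound and lower numbers for an effect already at smaller amounts. Of the two compounds measured, compound 2 stands at the higher number: in this assay compound 2 gives 12 nM, while compound 1 gives 1 nM, and the gap between them lies beyond the scatter of repeated measurements. The two compounds differ in more than one place, so nothing can be said about which part of either structure accounts for that gap.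

Compound 3, `[O-][n+]1ccccc1C1CCN(Cc2nc3ccccc3[nH]2)CC1`, has not been measured. It differs from compound 2 in a single place: a group of 7 heavy atoms (5 carbon, 1 nitrogen, 1 oxygen; one six-membered aromatic ring with 1 hetero atom) in place of a group of 6 heavy atoms (5 carbon, 1 nitrogen; one six-membered aromatic ring with 1 hetero atom), on a saturated ring carbon. In words, a group of 7 heavy atoms (5 carbon, 1 nitrogen, 1 oxygen; one six-membered aromatic ring with 1 hetero atom) takes the place of a group of 6 heavy atoms (5 carbon, 1 nitrogen; one six-membered aromatic ring with 1 hetero atom), on a saturated ring carbon. The rest of compound 2 is kept unchanged.

Going by the values given here, no pair of measured compounds shows a change of this kind, so the step has no direct precedent here. The expectation is a modest step from compound 2 to compound 3 toward a higher number, a 2.5-fold higher number from compound 2 to compound 3 (0.40 log units; beyond the scatter), with a real chance that it stays within the scatter. Compound 3 is therefore estimated at 30 nM in this assay, within a range from 8 nM to 120 nM.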

Compound 3, half-maximal effective concentration: 54 nM
Compound 3: the middle estimate sits 1.8-fold (0.26 log units) below what was measured; measured number inside the range.
By their numbers in this assay, from the lowest: compound 1; then compound 2; then compound 3.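

Going by these compounds alone, compound 2 and compound 3 form the first pair here that differs in only one place, so this is the first direct reading of a change on the saturated ring carbon, three ring bonds from the ring nitrogen. Swapping pyridin-2-yl for the group with one more oxygen atom moves the number upward in this assay (a 4.5-fold higher number from compound 2 to compound 3 (0.65 log units; beyond the scatter)), even though both groups have the same six-membered aromatic ring, the same counts of hydrogen-bond donors and acceptors, and no net charge, so a difference of one oxygen atom at this position is enough to produce a step beyond the scatter. No measured property of these compounds is available to explain this step.

A single pair cannot show whether other groups at this position, such as a plain phenyl ring or a pyridin-4-yl ring, would give a lower or a higher number than pyridin-2-yl. As far as these compounds go, it also remains open whether adding the same oxygen atom to the thiazole-bearing compound 1 or to another core would raise the number in the same way.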